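From compound 2 to compound 4: a swap on the sulfonyl sulfur

The compounds below may be only part of what the source reports. "The series", "measured", "known", "first", "only" and "open" are said of these compounds alone.

Compound 1 `Cc1cc(C)c(S(=O)(=O)N2CCN(C3CN4CCC3CC4)CC2)c(C)c1`: limit > 5000 nM
Compound 2 `Cc1noc(C)c1S(=O)(=O)N1CCC(N2CCC(C)CC2)CC1`: limit > 10000 nM
Compound 3 `Cc1c(C)c(S(=O)(=O)N2CCC(N3CCC(C)CC3)CC2)c(C)c2c1OC(C)(C)C2`: limit > 10000 nM

All three compounds were tested in an ADME assay on HCT-116 cells (Homo sapiens) for cytotoxicity, read by CellTiter-Glo, with a stated time of 72 h (a lower number here means a stronger inhibitor, a higher number a weaker inhibitor), and none of them yields a number. Compound 2 stands at the limit of > 10000 nM in this assay, at which 2 of the 3 values shown sit, and has only this limit to its name. Compound 3 shares that limit. Compound 1 stands at the limit of > 5000 nM in this assay, at which 1 of the 3 values shown sits, and this too is a limit. For the measured compounds named here, no two measured compounds differ in a single place, so the data offer no measured step to carry over.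

Compound 4 `CC1CCN(C2CCN(S(=O)(=O)c3cccnc3)CC2)CC1` has not yet been measured. It carries pyridin-3-yl in place of 3,5-dimethyl-1,2-oxazol-4-yl on a sulfonyl sulfur and otherwise matches compound 2.

The expectation starts from compound 2 and its limit of > 10000 nM as the only anchor. In this assay the expected step is no more than the usual scatter, in no firm direction: a step that the limit leaves unreadable from compound 2 to compound 4 is the estimate. A report of a limit alone is expected to be the likeliest outcome. Compound 4 is estimated at 12000 nM with an expected range from 5000 nM to 30000 nM as its span.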

Compound 4, half-maximal inhibitory concentration: > 10000 nM
Compound 4: a limit, no number (the forecaster's own chance of this, stated with the estimate: 85%); the middle value does not contradict the limit.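

Compound 2 and compound 4 each give a limit rather than a number, and no step can be read between them. The compounds shown leave open how far any of them lies from its limit, and whether any group on the sulfonyl sulfur would give a number in this assay.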